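Chloro on the pyridine ring: thiourea and urea pairs

The compounds below may be only part of what the source reports. "The series", "measured", "known", "first", "only" and "open" are said of these compounds alone.

Compound 2 `Nc1ccccc1NC(=O)c1ccc(NC(=S)NCc2cccnc2)cc1` and compound 1 `Nc1ccccc1NC(=O)c1ccc(NC(=S)NCc2ccc(Cl)nc2)cc1` share one core. In a functional assay on HepG2 cells (Homo sapiens) for cytotoxicity, read by MTT assay, with a stated time of 72 h (on this read-out higher numbers stand for weaker inhibition and lower numbers for stronger inhibition), compound 2 gives 4200 nM and compound 1 gives 19000 nM; the change chloro in place of hydrogen on an aromatic carbon made a 4.5-fold higher number from compound 2 to compound 1 (0.66 log units; beyond the scatter). Compound 3 `Nc1ccccc1NC(=O)c1ccc(NC(=O)NCc2cccnc2)cc1` gives 5100 nM in this assay; how its core differs from that of compound 2 is not broken down here. Compound 4 `Nc1ccccc1NC(=O)c1ccc(NC(=O)NCc2ccc(Cl)nc2)cc1` is not yet measured in this assay and differs from compound 3 by chloro in place of hydrogen on an aromatic carbon, at the same place as in the earlier pair, so the same change. In this assay the expected step is a 3.9-fold higher number from compound 3 to compound 4 (0.59 log units; beyond the scatter). This expectation rests on a 4.5-fold higher number from compound 2 to compound 1 (0.66 log units; beyond the scatter) for the same change on the other core, with added uncertainty from the untested core. Compound 4 is thus estimated at 20000 nM in this assay, between 8000 nM and 50000 nM.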

Compound 4, half-maximal inhibitory concentration: 2400 nM
For compound 4 the middle estimate is 8.3-fold (0.92 log units) above the measured one, outside the stated range (below it).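

Chloro in place of hydrogen gives a 2.1-fold lower number from compound 3 to compound 4 (0.33 log units; beyond the scatter) in this assay, the opposite direction to the step on the core of compound 2. The change therefore does not carry over as a fixed step between these two cores: the same change on two cores in this assay, a 4.5-fold higher number (0.66 log units; beyond the scatter) from compound 2 to compound 1 and a 2.1-fold lower number (0.33 log units; beyond the scatter) from compound 3 to compound 4, 9.6-fold (0.98 log units) apart, beyond the scatter of two such steps. Going by these compounds alone, with only two pairs, this shows that the outcome of the change depends on the core, but it does not show which feature of the core matters or give a rule for other cores.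

On these data alone, whether bromo, methyl or methoxy in place of chloro would follow the step on the core of compound 2 or the one on the core of compound 3 remains open. So does the effect of a longer chain in place of the methyl link to the ring.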